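A few compounds are considered here, and "the series" means these few. Any claim that something is new, unique, unknown or untested is made for them only; others in the source may bear on it.

Working notes on the series in a functional assay on OVCAR-4 cells (Homo sapiens) for cytotoxicity, read by sulforhodamine B assay, with a stated time of 48 h, tested at 0.01 uM; a lower number here means a stronger effect, a higher number a weaker effect of the compound at the concentration tested. Compound 1 `COc1cc(-c2cc(/C=C/C(=O)c3ccc(N)cc3)[nH]n2)cc(OC)c1OC` gives 85% in this assay. Compound 2 `COc1ccc(-c2cc(/C=C/C(=O)c3ccc(N)cc3)[nH]n2)cc1OC` gives 85% in this assay, and the step from compound 1 to compound 2 is no change at the digits printed from compound 1 to compound 2 (within the scatter), so compound 1 stands level with compound 2 at the digits shown; neither compound shows a strong effect at this concentration.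

Compound 3 `COc1cc(-c2cc(/C=C/C(=O)c3ccc(F)c(F)c3)[nH]n2)cc(OC)c1OC` is not yet measured. It differs from compound 1 in one place: 3,4-difluorophenyl in place of 4-aminophenyl on a carbonyl carbon. For the measured compounds named here, the only measured step, from compound 1 to compound 2, concerns a methoxy on the shared core and leaves the 4-aminophenyl untouched, so no measured step bears directly on the exchange made in compound 3. Going by the values given here, what the two values show is that the core with either methoxy pattern sits at a weak effect, and a change on the carbonyl-bound ring has no precedent here.

The expected step from compound 1 to compound 3 is therefore a number 2 percentage points higher from compound 1 to compound 3 (within the scatter), not beyond the scatter. For compound 3 the estimated value in this assay is 87%, with a range from 70% to 100%.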

Compound 3, a percentage reported as activity, at one concentration (the size of the read-out at that concentration, not a potency): 90%
Beside the measured number, compound 3's estimate is 3 percentage points below it; the range from low to high includes it.
By their numbers in this assay, from the lowest: compounds 1, 2 and 3 (each within the scatter of the next).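

In this assay, for the compounds shown here, the exchange on the carbonyl carbon gives a number 5 percentage points higher from compound 1 to compound 3 (within the scatter), the first reading at this place, where the earlier pair spoke only to a methoxy on the shared core. At this single concentration, the read-out therefore does not separate 4-aminophenyl, with 1 hydrogen-bond donor and 1 hydrogen-bond acceptor, from 3,4-difluorophenyl, with 0 of either, so this place tolerates that exchange without a step beyond the scatter. No measurement bearing on this result is available, and the data offer no explanation for it.

Still open, from the compounds shown here alone, is whether a different group on the carbonyl carbon, such as a plain phenyl, a carboxylic acid-bearing phenyl or a pyridine ring, would also stay within the scatter of compound 1, and whether 3,4-difluorophenyl would read the same on the core of compound 2. Also open is whether 4-aminophenyl and 3,4-difluorophenyl would separate at higher concentrations, since the compounds shown all sit at one concentration where none shows a strong effect.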